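From Methyl to Bromo on a Sulfonamide Series

A few compounds are considered here, and "the series" means these few. Any claim that something is new, unique, unknown or untested is made for them only; others in the source may bear on it.

Of the compounds shown here, three have been tested in a functional assay on HEK293 cells for agonist activity at probable G-protein coupled receptor 27 (Homo sapiens), read by a luciferase reporter and beta-arrestin recruitment, with a stated time of 10 min; on this read-out higher numbers stand for an effect only at larger amounts of compound and lower numbers for an effect already at smaller amounts. Compound 1, `O=C(NS(=O)(=O)c1ccc(NC(=O)c2ccc(Cl)cc2Cl)cc1)c1ccccc1`, gave only a limit of the assay, > 100000 nM, and not a number. Compound 2, `O=C(Nc1cccc(S(=O)(=O)Nc2ccccc2)c1)c1ccc(Cl)cc1Cl`, likewise gave only a limit, > 100000 nM. Among the measured compounds shown here, compound 3, `Cc1cc(Cl)ccc1C(=O)Nc1ccc(S(=O)(=O)Nc2ccccc2)cc1`, is the one member with a measured number: in this assay compound 3 gives 912 nM. So compound 3 stands alone as the only value that is an actual number, the other two results sitting at the limit of > 100000 nM in this assay, at which 2 of the 3 values shown sit.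

Compound 4, `O=C(Nc1ccc(S(=O)(=O)Nc2ccccc2)cc1)c1ccc(Cl)cc1Br`, has not yet been measured. It differs from compound 3 in one place: bromo in place of methyl on an aromatic carbon. In plainer words, a bromo group takes the place of a methyl group on an aromatic carbon.

For the measured compounds named here, no step between two measured compounds is available to show what such an exchange does in this assay. The swap keeps the count of heavy atoms the same and changes neither donors nor acceptors nor charge, so the step is expected to be modest and without a clear direction; the expected step of a 1.1-fold higher number from compound 3 to compound 4 (0.04 log units; within the scatter) is essentially none beyond the usual scatter. Compound 4 is therefore expected to give about 1000 nM, with a range from 300 nM to 4000 nM.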

Compound 4, half-maximal effective concentration: 1020 nM
Beside the measured number, compound 4's estimate is 1.0-fold (0.01 log units) below it; low and high end bracket the measured number.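

In this assay, placing bromo where methyl stood, on an aromatic carbon ortho to a large group, amounts to a 1.1-fold higher number from compound 3 to compound 4 (0.05 log units; within the scatter), so the two compounds cannot be told apart on this read-out. This is the only pair shown that differs in one place, and it gives the first direct reading at this position: the 4-chloro-2-methylphenyl and 2-bromo-4-chlorophenyl groups read alike here, and compound 4 joins compound 3 as a second compound with a real number rather than a limit. Nothing measured here bears on why the two groups read alike.

The compounds shown leave open how far this position accepts groups of a different kind, such as a hydroxyl, an amine or a carboxylic acid, or a longer chain such as propyl, in place of the methyl or the bromo. Equally open, going by these compounds, is what a plain hydrogen or a methoxy group on the same carbon would give, and whether the exchange of methyl for bromo would also read alike on a different core.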